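The source may report more compounds than this note shows. Statements on the series, on what has been measured and on what is new or still open speak of the compounds shown alone.

In a functional assay on HL-60 cells (Homo sapiens) for inhibition, read by CCK-8 assay, with a stated time of 48 h (a lower number here means a stronger inhibitor, a higher number a weaker inhibitor), compound 2 `Cc1ccc(-c2ccsc2S(=O)(=O)NCCNC(=O)Nc2cc(Cl)cc(Cl)c2)c(Oc2ccc(O)c(O)c2)c1` gives 3500 nM and compound 1 `COc1ccc(NC(=S)NCCNS(=O)(=O)c2sccc2-c2ccc(C)cc2Oc2ccc(O)c(O)c2)cc1` gives 4100 nM so the two stand level within the scatter. Compound 3 `Cc1ccc(-c2ccsc2S(=O)(=O)NCCNC(=O)Nc2cccc([N+](=O)[O-])c2)c(Oc2ccc(O)c(O)c2)c1` differs from compound 2 by one change (3-nitrophenyl in place of 3,5-dichlorophenyl on an amide-type nitrogen) with 3-nitrophenyl in place of 3,5-dichlorophenyl on an amide-type nitrogen. Among the measured compounds shown here, the one measured step (a 1.2-fold lower number from compound 1 to compound 2 (0.07 log units; within the scatter)) also exchanged a group holding a six-membered aromatic ring and stayed within the scatter. No step beyond the scatter is therefore expected in this assay and the expected step is small (a 1.3-fold higher number from compound 2 to compound 3 (0.11 log units; within the scatter)). The estimate for compound 3 is 4500 nM (expected range 2000 nM to 10000 nM).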

Compound 3, half-maximal inhibitory concentration: 6000 nM
For compound 3 the middle estimate is 1.3-fold (0.12 log units) below the measured one; measured number inside the range.
By their numbers in this assay, from the lowest: compounds 2, 1 and 3 (each within the scatter of the next).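

In this assay, 3-nitrophenyl in place of 3,5-dichlorophenyl on the amide-type nitrogen gives a step within the scatter (a 1.7-fold higher number from compound 2 to compound 3 (0.23 log units; within the scatter)), as does the exchange against the group of compound 1 (a 1.5-fold higher number from compound 1 to compound 3 (0.17 log units; within the scatter)). This position therefore holds a third substituted phenyl group, with 2 hydrogen-bond acceptors where 3,5-dichlorophenyl has 0, without a step beyond the scatter. No measurement at hand bears on the cause of this result.

Open, going by these compounds, is whether a phenyl ring carrying an amine or a carboxylic acid, or a plain alkyl chain in place of the ring, would give a step beyond the scatter.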